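The source may report more compounds than this note shows. Statements on the series, on what has been measured and on what is new or still open speak of the compounds shown alone.

Measured so far in a functional assay on OVCAR-3 cells (Homo sapiens) for inhibition, read by sulforhodamine B assay, with a stated time of 48 h; on this read-out higher numbers stand for lower toxicity in this test and lower numbers for higher toxicity in this test:
compound 1 `Nc1cc(N)c2nc(-c3ccccc3)c(Oc3ccc(Cl)c(Cl)c3)nc2c1` gives 66100 nM.
Compound 2 `COc1ccc(Sc2nc3cc(N)cc(N)c3nc2-c2ccccc2)cc1` gives only a limit of the assay, < 100000 nM.

Compound 2 thus stands on this assay with a limit and no number. Within the data shown here, the one comparison that reaches it is a step that the limit leaves unreadable from compound 1 to compound 2, and the reason is the limit of < 100000 nM in this assay, at which 1 of the 2 values shown sits. Compound 3 `Nc1cc(N)c2nc(-c3ccccc3)c(Sc3ccc(Cl)c(Cl)c3)nc2c1` differs from compound 2 by 3,4-dichlorophenyl in place of 4-methoxyphenyl on a sulfur. Among the measured compounds shown here, since the only measured step that touches compound 2 is of unreadable size, nothing measured fixes the size of the step to compound 3 in this assay. The nearest point of reference is compound 1, which carries the same 3,4-dichlorophenyl ring on an oxygen and gives 66100 nM in this assay. Compound 3 is expected to land near that value, at an estimated 50000 nM, within 15000 nM to 100000 nM. The expected step is a step that the limit leaves unreadable from compound 2 to compound 3.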

Compound 3, concentration lethal to 50% of the cells: < 100000 nM
Compound 3 ended at the assay's limit (the forecaster's own chance of this, stated with the estimate: 30%); the middle value is on the limit's open side.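

No step can be read from compound 3 to compound 1 or compound 2 in this assay, because compound 2 and compound 3 each give only a limit: the limit of < 100000 nM in this assay, at which 2 of the 3 values shown sit.

The compounds shown leave open the size of any effect of exchanging 4-methoxyphenyl for 3,4-dichlorophenyl on a sulfur, or of exchanging the oxygen of compound 1 for the sulfur of compound 3.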